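From Pyridin-3-yl to Trifluoromethyl on the Shared Core

The compounds below may be only part of what the source reports. "The series", "measured", "known", "first", "only" and "open" are said of these compounds alone.

Compound 1 `CN(C(=O)c1cc(F)ccc1O)c1ccc(C#N)cc1` and compound 2 `N#Cc1ccc(NS(=O)(=O)c2cc(F)ccc2O)cc1` belong to the same small set as the pair followed here. In a functional assay on HL-60 cells (Homo sapiens) for cytotoxicity, read by luminescence and CellTiter-Glo, with a stated time of 3 days (on this read-out higher numbers stand for weaker inhibition and lower numbers for stronger inhibition), compound 1 gives only a limit, > 10000 nM, and not a number. Compound 2 likewise reaches only a limit in this assay, > 10000 nM. Most of what is known so far is therefore (the limit of > 10000 nM in this assay, at which 2 of the 3 values shown sit). Going by the values given here, compound 3 `N#Cc1ccc(NC(=O)c2cc(-c3cccnc3)ccc2O)cc1` is the one compound with a number, giving 7960 nM in this assay, which leaves it standing alone among the results rather than ranked against the others. Compound 4 `N#Cc1ccc(NC(=O)c2cc(C(F)(F)F)ccc2O)cc1` has not yet been measured. The change from compound 3 to compound 4 is trifluoromethyl in place of pyridin-3-yl on an aromatic carbon, a trifluoromethyl put in place of pyridin-3-yl on an aromatic carbon, meta to a large group and para to a hydroxy group. Among the compounds with values here, no measured pair in this set differs in one place, so no earlier step tells how large such a change runs. In this assay the expected step from compound 3 to compound 4, a 1.0-fold higher number from compound 3 to compound 4 (0.00 log units; within the scatter), is small, within the scatter of repeated runs in either direction. Compound 4 is estimated at 8000 nM, with a range from 3000 nM to 20000 nM, and a real chance that only a limit is reported.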

Compound 4, half-maximal inhibitory concentration: 3120 nM
Beside the measured number, compound 4's estimate is 2.6-fold (0.41 log units) above it, within the range that was stated.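

In this assay the change from pyridin-3-yl to trifluoromethyl gives a 2.6-fold lower number from compound 3 to compound 4 (0.41 log units; beyond the scatter) and so shows that the number responds to what sits at this position, para to a hydroxy group. Going by these compounds alone, this is the first pair in the set that differs in one place, which gives the first measured size for a change on the shared core, and here the entering group has no ring, yet inhibition is stronger. The data shown give no measured property of either group that would explain this step.

From the compounds shown here alone, whether an amine, a carboxylic acid or a longer chain at this position would give a lower or a higher number stays open. Going by these compounds, with a single pair, it also stays open whether the same change would give a step of similar size on another core.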